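The source may hold more compounds than are shown below. What is called first, only, known or untested is meant among the compounds shown, and "the series" means these compounds.

In a functional assay on the whole organism (strain Wistar) for inhibition, with Rattus norvegicus as the target, read by paw edema, with stated times of 60 min and 3 h, at a dose of 100 mg/kg by the oral route (on this read-out higher numbers stand for more inhibition at the one dose given (going by the name of the read-out) and lower numbers for less inhibition), compound 1, with structure `COc1cc2c(cc1OC)C(CC(=O)NC(C)C)CC2`, gives 30.4%, while compound 2, with structure `COc1cc2c(cc1OC)C(CC(=O)NC1CCCC1)CC2`, gives 43.5%. Among the compounds with values here, the only recorded step, a number 13.1 percentage points higher from compound 1 to compound 2 (beyond the scatter), places compound 2 at the upper end of the two numbers, beyond the scatter from compound 1.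

Compound 3, with structure `COc1cc2c(cc1OC)C(CC(=O)N1CCCC1)CC2`, has not yet been measured. Its difference from compound 2 is pyrrolidin-1-yl in place of cyclopentylamino on a carbonyl carbon.

Within the data shown here, no recorded step touches this kind of change. Among the measured compounds shown here, the one step known, a number 13.1 percentage points higher from compound 1 to compound 2 (beyond the scatter), concerns a larger carbon ring in place of a branched chain on the amide-type nitrogen while the hydrogen-bond donor stays; here the donor leaves and the ring closes onto the nitrogen. That step offers no basis for predicting a direction, so no move beyond the scatter is expected for compound 3 in this assay.

Compound 3 is therefore expected to give about 38% in this assay, within a range of 20% to 55%, which amounts to an estimated step of a number 5.5 percentage points lower from compound 2 to compound 3 (within the scatter).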

Compound 3, a percentage reported as inhibition, in the whole organism at one dose (the size of the read-out at that dose, not a potency): 26.1%
Beside the measured number, compound 3's estimate is 11.9 percentage points above it; the range from low to high includes it.
By their numbers in this assay, from the lowest: compounds 3 and 1 (each within the scatter of the next); then compound 2.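

In this assay this position on the carbonyl carbon proves sensitive to more than the size of the carbon ring: pyrrolidin-1-yl in place of cyclopentylamino, a change in which the hydrogen-bond donor leaves and the ring closes onto the nitrogen, brings a number 17.4 percentage points lower from compound 2 to compound 3 (beyond the scatter) and so cancels the advantage that compound 2 held over compound 1. The same exchange made on the smaller group, pyrrolidin-1-yl in place of isopropylamino, gives a number 4.3 percentage points lower from compound 1 to compound 3 (within the scatter), so the amide hydrogen alone does not separate these compounds: compound 1 carries it, yet it stands within the scatter of compound 3, which lacks it, and only compound 2 stands apart. Nothing at hand explains the fall from cyclopentylamino to pyrrolidin-1-yl.

The compounds shown leave open whether the loss follows from removing the amide hydrogen or from moving the ring onto the nitrogen, a question that a cyclopentylamino group carrying a methyl on its nitrogen would address directly. They also leave open how a larger ring would behave here, whether as cyclohexylamino, piperidin-1-yl or morpholin-4-yl.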